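A Thiophene Variant in a Cytotoxicity Series

The source may report more compounds than this note shows. Statements on the series, on what has been measured and on what is new or still open speak of the compounds shown alone.

Compound 1 `COc1cccc(/C=N/NC(=O)CSc2nnc(-c3ccncc3)o2)c1`: 15800 nM
Compound 2 `O=C(CSc1nnc(-c2ccncc2)o1)N/N=C/c1ccccc1O`: 6160 nM

Of the compounds shown here, two have been measured in a functional assay on BGC-823 cells (Homo sapiens) for cytotoxicity, read by MTT assay, with a stated time of 48 h; a higher number here means a weaker inhibitor, a lower number a stronger inhibitor. In this assay compound 1 gives 15800 nM, and compound 2 gives 6160 nM. Among the two numbers, compound 2 stands lowest, and the one step known, a 2.6-fold lower number from compound 1 to compound 2 (0.41 log units; beyond the scatter), sets it apart from compound 1.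

Compound 3 `O=C(CSc1nnc(-c2ccncc2)o1)N/N=C/c1cccs1` is not yet measured. It differs from compound 2 in one place: thiophen-2-yl in place of 2-hydroxyphenyl on a carbon with a double bond to nitrogen. For the measured compounds named here, the only measured step, a 2.6-fold lower number from compound 1 to compound 2 (0.41 log units; beyond the scatter), also changed the group on this carbon, and it was modest. It does not involve thiophen-2-yl, so it bears on the new change only by showing that a swap at this place can move the number modestly. With the 2-hydroxyphenyl of compound 2 giving the lowest number seen, a modest rise is expected for compound 3, as a 1.6-fold higher number from compound 2 to compound 3 (0.21 log units; within the scatter). Compound 3 is therefore estimated at 10000 nM, between 3500 nM and 30000 nM.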

Compound 3, half-maximal inhibitory concentration: 26700 nM
Beside the measured number, compound 3's estimate is 2.7-fold (0.43 log units) below it, within the range that was stated.
By their numbers in this assay, from the lowest: compound 2; then compounds 1 and 3 (each within the scatter of the next).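

In this assay the change on this carbon gives a 4.3-fold higher number from compound 2 to compound 3 (0.64 log units; beyond the scatter) and so gives up the low number that the 2-hydroxyphenyl of compound 2 reached. The other new pair gives a 1.7-fold higher number from compound 1 to compound 3 (0.23 log units; within the scatter) and lies within the scatter, so thiophen-2-yl and 3-methoxyphenyl cannot be told apart here, and among the three groups on the carbon with a double bond to nitrogen, only the 2-hydroxyphenyl has steps beyond the scatter to both others. The change from compound 2 to compound 3 removes a hydrogen-bond donor and replaces a six-membered aromatic ring of carbon with a five-membered one holding sulfur, but nothing measured here separates these differences or explains the rise.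

The compounds shown leave open whether the hydroxyl of compound 2 alone accounts for its number, a question that a plain phenyl or a 2-aminophenyl on the same carbon would address. They also leave open how a furan-2-yl would compare with thiophen-2-yl, and whether a carboxylic acid on the phenyl ring would move the number in either direction.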